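This account rests on a few compounds, and the source may have more. Where it says the series, first, only, none or still open, it means among the compounds named here.

Of the compounds shown here, two have been measured in a functional assay on ACHN cells (Homo sapiens); on this read-out higher numbers stand for weaker inhibition of growth and lower numbers for stronger inhibition of growth. Compound 1 `O=S(=O)(/C=C/c1ccccc1)Cc1ccc(Nc2ncnc3ccccc23)cc1` gives 58000 nM. Compound 2 `O=S(=O)(/C=C/c1ccc(Br)cc1)Cc1ccc(Nc2ncnc3ccccc23)cc1`, which carries bromo in place of hydrogen on an aromatic carbon, gives 200 nM. The step of a 290-fold lower number from compound 1 to compound 2 (2.46 log units; beyond the scatter) is the only one available, and it leaves compound 2 with the lowest of the two numbers, compound 1 standing far higher.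

Compound 3 `O=S(=O)(/C=C/c1ccc(C(F)(F)F)cc1F)Cc1ccc(Nc2ncnc3ccccc23)cc1` is not yet measured. It differs from compound 2 by 2-fluoro-4-(trifluoromethyl)phenyl in place of 4-bromophenyl on a double-bonded chain carbon bound to a double-bonded chain carbon. Among the compounds with values here, the one measured step bears on this change only in part: it shows that the group at the same position of the cinnamyl-type ring can shift the number very strongly, but nothing has been measured with a trifluoromethyl or with a second fluorine on that ring. The direction is therefore uncertain; a number of the same order as that of compound 2 is expected, with a wide range, and the expected step of a 2.0-fold higher number from compound 2 to compound 3 (0.30 log units; within the scatter) is modest. Compound 3 is estimated at 400 nM, expected to lie between 80 nM and 3000 nM.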

Compound 3, concentration for 50% growth inhibition: 100000 nM
Compound 3: middle estimate off by 250-fold (2.40 log units), on the low side; measured number above the stated range.
By their numbers in this assay, from the lowest: compound 2; then compounds 1 and 3 (each within the scatter of the next).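

In this assay, the step of a 500-fold higher number from compound 2 to compound 3 (2.70 log units; beyond the scatter) shows that the low number of compound 2 does not extend to every substituted ring on this double-bonded chain carbon: replacing 4-bromophenyl with 2-fluoro-4-(trifluoromethyl)phenyl removes the whole of the earlier gain. The step of a 1.7-fold higher number from compound 1 to compound 3 (0.24 log units; within the scatter) lies within the scatter, so compound 3 cannot be told apart from compound 1, which carries plain phenyl, and among these three compounds only compound 2, with its 4-bromophenyl, stands apart. Nothing shown gives a measured reason for this sharp dependence on the ring, and the data alone cannot supply one.

Since compound 3 differs from compound 2 in both the fluoro and the trifluoromethyl as well as in the loss of bromo, it remains open which of these changes accounts for the step, and a ring carrying only the trifluoromethyl or only the fluoro would separate them. Going by these compounds, it is also open whether the low number belongs to bromo alone or is shared by other groups in its place, such as chloro, iodo, methoxy or an amine.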